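This account rests on a few compounds, and the source may have more. Where it says the series, first, only, none or still open, it means among the compounds named here.

Values in a functional assay on MCF7 cells (Homo sapiens) for inhibition, read by MTT assay, with a stated time of 48 h, tested at 10 uM; a lower number here means less inhibition of growth, a higher number more inhibition of growth at the concentration tested:

compound 1 `C#CCOc1ccc(/C=C/C(=O)c2ccc(Br)cc2)cc1`: 45%
compound 2 `O=C(/C=C/c1ccc(OCc2cn(Cc3cccc(Br)c3)nn2)cc1)c1ccc(Br)cc1`: 36%
compound 3 `COc1ccc(C(=O)/C=C/c2ccc(OCc3cn(Cc4cccc(Br)c4)nn3)cc2)cc1`: 45%

Compound 3 stands level with compound 1 at the digits shown in this assay; the only single-point step in the set is a number 9 percentage points higher from compound 2 to compound 3 (within the scatter), methoxy in place of bromo on an aromatic carbon, within the scatter. Compound 4 `COc1ccc(C(=O)/C=C/c2ccc(OCc3cn(Cc4ccc(F)cc4)nn3)cc2)cc1` differs from compound 3 by 4-fluorophenyl in place of 3-bromophenyl on a saturated chain carbon bound to an aromatic nitrogen. Among the compounds with values here, no measured step touches the benzyl group on the triazole nitrogen, so nothing in the set bears directly on this change; the one step recorded, a number 9 percentage points higher from compound 2 to compound 3 (within the scatter), sits elsewhere and was itself within the scatter. No step beyond the scatter is therefore expected in this assay. Compound 4 is estimated at 44%, range 28% to 60%, meaning an expected step of a number 1 percentage points lower from compound 3 to compound 4 (within the scatter).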

Compound 4, percent growth inhibition at one concentration: 15%
Estimate against measurement, compound 4: 29 percentage points above; the whole stated range lies above it.
By their numbers in this assay, from the lowest: compound 4; then compounds 2, 1 and 3 (each within the scatter of the next).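

In this assay, within the data shown here, the benzyl position, which no earlier step touched, gives the first single change beyond the scatter: a number 30 percentage points lower from compound 3 to compound 4 (beyond the scatter). The 3-bromophenyl and 4-fluorophenyl groups match in heavy atoms, rings, donors and acceptors, so those counts do not separate them. Nothing measured here accounts for the drop.

The halogen and its place change together, so the compounds shown leave open which of the two carries the step. A 4-bromophenyl or 3-fluorophenyl group would separate them, and an amine at this position remains an open case.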